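Triazole-bearing bicyclic ketones: cytotoxicity toward breast cancer cells

The source may report more compounds than this note shows. Statements on the series, on what has been measured and on what is new or still open speak of the compounds shown alone.

Measured so far:
compound 1 `CCCCn1cc(CO[C@H]2CC(=O)[C@@H]3OC[C@H]2O3)nn1`: 27900 nM
compound 2 `CC(=O)N(Cc1cn(Cc2ccccc2)nn1)[C@H]1CC(=O)[C@@H]2OC[C@H]1O2`: > 50000 nM
compound 3 `COC(=O)Cn1cc(CN(C(C)=O)[C@H]2CC(=O)[C@@H]3OC[C@H]2O3)nn1`: > 50000 nM

In a functional assay on MDA-MB-231 cells (Homo sapiens) for cytotoxicity, read by MTT assay, with a stated time of 48 h (a lower number here means a stronger inhibitor, a higher number a weaker inhibitor), compound 1 gives 27900 nM. For compound 2 the reading is a limit of the assay, > 50000 nM. For compound 3 the reading is likewise a limit, > 50000 nM. Within the data shown here, compound 3 thus stands at the limit of > 50000 nM in this assay, at which 2 of the 3 values shown sit, and the only step that touches it, a step that the two limits leave unreadable from compound 2 to compound 3, cannot be sized because both ends are limits.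

Compound 4 `CC(=O)N(Cc1cn(C(=O)c2ccccc2)nn1)[C@H]1CC(=O)[C@@H]2OC[C@H]1O2` differs from compound 3 by benzoyl in place of (methoxycarbonyl)methyl on an aromatic nitrogen. Among the measured compounds shown here, no measured step covers this change. For the measured compounds named here, the one step that alters the substituent on the aromatic nitrogen, a step that the two limits leave unreadable from compound 2 to compound 3, is unreadable, and it ends at the same limit from which compound 4 departs. Nothing in the series therefore points to a gain beyond the scatter, and the most probable outcome is that compound 4 again returns a limit. Compound 4 is estimated at 60000 nM, within 20000 nM to 200000 nM, the expected step being a step that the limit leaves unreadable from compound 3 to compound 4.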

Compound 4, half-maximal inhibitory concentration: > 50000 nM
Compound 4: a limit, no number; the forecaster's own chance of this, stated with the estimate: 70%; the middle value does not contradict the limit.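

Compound 4 returns a limit, as do compound 2 and compound 3, so no step among these three can be read: the limit of > 50000 nM in this assay, at which 3 of the 4 values shown sit. Still open, as far as these compounds go, is how far benzoyl, benzyl and (methoxycarbonyl)methyl on the aromatic nitrogen differ from one another in this assay.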